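Ring-fused acids: defining the stereo elements of compound 2

The compounds below may be only part of what the source reports. "The series", "measured", "known", "first", "only" and "open" are said of these compounds alone.

- compound 1 `CC1CCCc2ncc(C(=O)O)c(=O)n21`: 240 umol/kg
- compound 2 `CC1CCC(=NNc2ccccc2)c2ncc(C(=O)O)c(=O)n21`: 0.6 umol/kg

In a functional assay on the whole organism with Rattus norvegicus as the target (on this read-out higher numbers stand for an effect only at larger amounts of compound and lower numbers for an effect already at smaller amounts), compound 1 gives 240 umol/kg and compound 2 gives 0.6 umol/kg; compound 2 has the lower of the two numbers, and its gap to compound 1 lies beyond the scatter.

Compound 3 `C[C@H]1CC/C(=N\Nc2ccccc2)c2ncc(C(=O)O)c(=O)n21` is to be measured in this assay. Its change from compound 2: the two compounds have the same atoms and bonds; at least one stereo element is drawn with a configuration in one of them and without one in the other: 2 of 2 stereo elements differ; a stereocentre at a saturated ring carbon is drawn without a configuration in compound 2 and S in compound 3; a double bond is drawn without a configuration in compound 2 and E in compound 3. No change of atoms or bonds is involved, so only a small step, if any, is expected, probably toward a lower number if compound 3 is the isomer that carries the effect of compound 2. Compound 3 is expected at 0.4 umol/kg, within 0.15 umol/kg to 2 umol/kg, a step of a 1.5-fold lower number from compound 2 to compound 3 (0.18 log units; within the scatter).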

Compound 3, dose for 50% inhibition: 0.3 umol/kg
The estimate for compound 3 lay 1.3-fold (0.12 log units) above the measured number; the measured number falls inside the stated range.
By their numbers in this assay, from the lowest: compounds 3 and 2 (each within the scatter of the next); then compound 1.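

With both stereo elements defined, S at the saturated ring carbon and E at the double bond, the series shows a 2.0-fold lower number from compound 2 to compound 3 (0.30 log units; within the scatter) in this assay. The defined form therefore keeps the effect of compound 2, which the undefined drawing alone could not show. The comparison concerns configuration only, and what separates the pair is this: the fact that one of compounds 2 and 3 is drawn with a defined configuration and the other without, at the place where they differ. From the compounds shown here alone, the contribution of each stereo element on its own stays open, as does the read-out of the R centre or the Z double bond. Also open, going by these compounds, is the effect of an ester or an amide in place of the carboxylic acid.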